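Methoxy to ethoxy on two cores in the aorta assay

The source may hold more compounds than are shown below. What is called first, only, known or untested is meant among the compounds shown, and "the series" means these compounds.

Compound 1 `COc1nc(-c2cc3ccccc3o2)cc(-c2cccc3ccccc23)c1C#N` and compound 2 `CCOc1nc(-c2cc3ccccc3o2)cc(-c2cccc3ccccc23)c1C#N` share one core; compound 3 `COc1nc(-c2cc3ccccc3o2)cc(-c2cccs2)c1C#N` and the unmeasured compound 4 `CCOc1nc(-c2cc3ccccc3o2)cc(-c2cccs2)c1C#N` share another, and the difference between the two cores is not broken down here. In a functional assay on aorta (strain Wistar) for inhibition, with Thoracic aorta (Rattus norvegicus) as the target (on this read-out lower numbers stand for stronger inhibition and higher numbers for weaker inhibition), compound 1 gives 359000 nM and compound 2 gives 344000 nM. The change between them, (methyl in place of hydrogen on a saturated chain carbon bound to an oxygen on an aromatic ring), made a 1.0-fold lower number from compound 1 to compound 2 (0.02 log units; within the scatter). Compound 3 gives 163000 nM in this assay, the lowest of the three numbers. Compound 4 carries the same change on its core, (methyl in place of hydrogen on a saturated chain carbon bound to an oxygen on an aromatic ring), at the same place word for word. Because the earlier step of a 1.0-fold lower number from compound 1 to compound 2 (0.02 log units; within the scatter) stayed within the scatter, the expected step of a 1.0-fold lower number from compound 3 to compound 4 (0.01 log units; within the scatter) is also taken to be small. Compound 4 is estimated at 160000 nM in this assay, expected between 80000 nM and 330000 nM.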

Compound 4, half-maximal inhibitory concentration: 308000 nM
Compound 4: the middle estimate sits 1.9-fold (0.28 log units) below what was measured; the range from low to high includes it.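

In this assay, methoxy to ethoxy on the second core gives a 1.9-fold higher number from compound 3 to compound 4 (0.28 log units; within the scatter) and the two cores do not differ beyond the scatter: the same change on two cores in this assay, a 1.0-fold lower number (0.02 log units; within the scatter) from compound 1 to compound 2 and a 1.9-fold higher number (0.28 log units; within the scatter) from compound 3 to compound 4, 2.0-fold (0.29 log units) apart, within the scatter of two such steps. On these two cores the change therefore carries over as a step within the scatter, but two pairs do not show that it would do so on any other core. At the ethoxy level, the aromatic swap gives a 1.1-fold lower number from compound 2 to compound 4 (0.05 log units; within the scatter) and also stays within the scatter, which is a single pair and shows nothing about other groups at that place.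

The compounds shown leave open whether a longer chain such as propoxy or butoxy, or an amine in place of the alkoxy group, would give a step beyond the scatter.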